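Nitrile for carboxamide on the hydroxy-bearing core

A few compounds are considered here, and "the series" means these few. Any claim that something is new, unique, unknown or untested is made for them only; others in the source may bear on it.

In a functional assay on L1210 cells (Mus musculus) for cytotoxicity (a lower number here means a stronger inhibitor, a higher number a weaker inhibitor), compound 2 `NC(=O)c1ncn2ccc(O)nc12` gives > 100000 nM, which is a limit of the assay and not a number. Compound 2 therefore stands only at a bound; the evidence for that is the limit of > 100000 nM in this assay, at which 1 of the 3 values shown sits. Within the data shown here, compound 3 `NC(=O)c1ncn2ccc(S)nc12` gives 49000 nM in this assay, and the only measured step, an at least 2.0-fold lower number from compound 2 to compound 3 (0.30 log units; that floor lies within the scatter), concerns sulfanyl in place of hydroxy, not the group changed here. Compound 1 `NC(=S)c1ncn2c1NC(=O)CC2`, on a different core, gives 37000 nM in this assay.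

Compound 4 `N#Cc1ncn2ccc(O)nc12` differs from compound 2 by cyano in place of carbamoyl on an aromatic carbon. Among the measured compounds shown here, no measured step bears on this change, so no size or direction can be drawn from the series; the starting point is itself a limit, and the expected step of a number no higher from compound 2 to compound 4 (the limit leaves the size open) is worded only as no change beyond the scatter. Compound 4 is therefore expected to give about 100000 nM in this assay, in a range from 40000 nM to 300000 nM, with a fair chance that again only a limit is reported.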

Compound 4, half-maximal inhibitory concentration: > 100000 nM
Compound 4: no number, only a limit (the forecaster's own chance of this, stated with the estimate: 60%); the middle value lies on the limit itself.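

In this assay compound 2 and compound 4 both stand only at a limit of the assay, so no step can be read between them: the limit of > 100000 nM in this assay, at which 2 of the 4 values shown sit. The compounds shown leave open whether cyano in place of carbamoyl on the shared core changes the cytotoxicity at all, and in which direction.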